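A few compounds are considered here, and "the series" means these few. Any claim that something is new, unique, unknown or untested is made for them only; others in the source may bear on it.

Compound 1 `Oc1ccccc1CNc1ncnc2c1ncn2C1CCCCO1`, compound 2 `COc1cccc(CNc2ncnc3c2ncn3C2CCCCO2)c1O` and compound 3 `COc1ccc(CNc2ncnc3c2ncn3C2CCCCO2)cc1OC` share one core and differ in the substitution of the benzyl ring. In an ADME assay on K562 cells (Homo sapiens) for cytotoxicity, with a stated time of 72 h (on this read-out lower numbers stand for stronger inhibition and higher numbers for weaker inhibition), compound 1 gives only a limit of the assay, > 100000 nM. In this assay compound 2 also gives only a limit, > 100000 nM. Compound 3 too returns only a limit in this assay, > 100000 nM. The change from compound 1 to compound 2, (methoxy in place of hydrogen on an aromatic carbon), gives a step that the two limits leave unreadable from compound 1 to compound 2 because of the limit of > 100000 nM in this assay, at which 3 of the 3 values shown sit. The difference between the cores of compound 1 and compound 3 is not broken down here. Compound 4 `COc1cc(OC)c(OC)cc1CNc1ncnc2c1ncn2C1CCCCO1` is not yet measured; it arises from compound 3 by the same kind of change, (methoxy in place of hydrogen on an aromatic carbon), now ortho to a large group, meta to a methoxy group and para to a methoxy group rather than ortho to a hydroxy group and meta to a large group. Compound 4 is expected to remain at the limit, so the step that the limit leaves unreadable from compound 3 to compound 4 is expected to be small. Compound 4 is estimated at 150000 nM, between 60000 nM and 500000 nM.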

Compound 4, half-maximal inhibitory concentration: > 100000 nM
Compound 4: only a limit was reported (the forecaster's own chance of this, stated with the estimate: 85%); the middle value is on the limit's open side.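

Among these compounds, compound 3 and compound 4 both return only a limit in this assay, so no step between them can be read: the limit of > 100000 nM in this assay, at which 4 of the 4 values shown sit. The compounds shown leave open how far each lies beyond that limit in this assay.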